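Working notes: from compound 2 to compound 3

The compounds below may be only part of what the source reports. "The series", "measured", "known", "first", "only" and "open" are said of these compounds alone.

For the measured compounds named here, compound 2 `CCN(Cc1ccccn1)c1ccc(C(=O)N2CCc3ccc(OS(N)(=O)=O)cc3C2)cc1` stands highest of the two numbers measured so far in an assay on HEK293 cells for inhibition of Steryl-sulfatase (Homo sapiens), tested at 0.1 uM (a higher number here means a stronger effect of the compound at the concentration tested, a lower number a weaker effect), where compound 2 gives 42.5%. Compound 1 `CCN(Cc1ccccc1)Cc1ccc(CN2CCc3ccc(OS(N)(=O)=O)cc3C2)cc1` gives 1% in this assay, and the gap between these two values lies beyond the usual scatter. Going by the values given here, the two compounds differ in more than one place, so the values show only that compound 2 sits well above compound 1; no single change is isolated by them.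

Compound 3 `CN(CCN1CCCCC1)c1ccc(C(=O)N2CCc3ccc(OS(N)(=O)=O)cc3C2)cc1` has not been measured. It differs from compound 2 in one place:

methyl(2-(piperidin-1-yl)ethyl)amino in place of ethyl((pyridin-2-yl)methyl)amino on an aromatic carbon

Among the compounds with values here, no step between measured compounds covers this change, and the pair of compound 1 and compound 2 does not speak to it. The expectation is therefore anchored on compound 2 with wide uncertainty: a step from compound 2 to compound 3 of a number 7.5 percentage points lower from compound 2 to compound 3 (within the scatter) is expected, a modest fall that may well lie within the scatter. Compound 3 is estimated at 35% in this assay, with a range from 10% to 62%.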

Compound 3, a percentage reported as inhibition, at one concentration (the size of the read-out at that concentration, not a potency): 0.3%
The estimate for compound 3 lay 34.7 percentage points above the measured number, and the stated range ends above it.
By their numbers in this assay, from the lowest: compounds 3 and 1 (each within the scatter of the next); then compound 2.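

Working notes: what the step from compound 2 shows

At this position, on an aromatic carbon para to a large group, the two amino substituents are not interchangeable in this assay: methyl(2-(piperidin-1-yl)ethyl)amino in place of ethyl((pyridin-2-yl)methyl)amino gives a number 42.2 percentage points lower from compound 2 to compound 3 (beyond the scatter), a large step and the first in the series that isolates a single place. The leaving and entering groups match in their counts of heavy atoms, carbon, nitrogen, hydrogen-bond donors and hydrogen-bond acceptors, and neither carries a net charge, so these counts do not separate the two compounds, whereas the six-membered aromatic ring of one against the six-membered non-aromatic ring of the other does differ. No measurement at hand accounts for the fall.

The change swaps the ring, the chain leading to it and the alkyl group on the aromatic amine nitrogen together, and the compounds shown do not assign the step to any one of these. A group such as methyl((pyridin-2-yl)methyl)amino or ethyl(2-(piperidin-1-yl)ethyl)amino at this position would separate the alkyl group from the rest, and a morpholine ring in place of the piperidine remains an open variation.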